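Triazolyl anilide sulfonamides: positional isomers in SGC-7901 cells

The source may report more compounds than this note shows. Statements on the series, on what has been measured and on what is new or still open speak of the compounds shown alone.

Measured so far:
compound 1, `Cc1cccc(-n2cc(-c3cccc(NS(=O)(=O)c4c[nH]c(=O)[nH]c4=O)c3)nn2)c1`: 9100 nM
compound 2, `Cc1ccc(-n2cc(-c3cccc(NS(=O)(=O)c4c[nH]c(=O)[nH]c4=O)c3)nn2)cc1`: 9430 nM
compound 3, `Cc1cccc(-n2cc(-c3ccc(NS(=O)(=O)c4c[nH]c(=O)[nH]c4=O)cc3)nn2)c1`: 17500 nM

All three were run in a functional assay on SGC-7901 cells (Homo sapiens) for antiproliferative activity, read by MTT assay, with a stated time of 24 h; a higher number here means a weaker inhibitor, a lower number a stronger inhibitor. The difference between the core of compound 1 and the core of compound 3 is not broken down here; their two values in this assay lie within the scatter of each other, as do those of compound 2 and compound 3, so no order among the three can be claimed. Among the compounds with values here, the one change that is counted, (4-methylphenyl in place of 3-methylphenyl on an aromatic nitrogen), gave a 1.0-fold higher number from compound 1 to compound 2 (0.02 log units; within the scatter), a step that lies within the scatter.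

Compound 4, `Cc1ccc(-n2cc(-c3ccc(NS(=O)(=O)c4c[nH]c(=O)[nH]c4=O)cc3)nn2)cc1`, is not yet measured. Within the data shown here, it is reached from compound 3 by 4-methylphenyl in place of 3-methylphenyl on an aromatic nitrogen, the same change as the one from compound 1 to compound 2, made around the same place. Because the step of a 1.0-fold higher number from compound 1 to compound 2 (0.02 log units; within the scatter) was within the scatter, the step of a 1.0-fold higher number from compound 3 to compound 4 (0.01 log units; within the scatter) is expected to be of a similar size, resting on that single pair alone. For compound 4 in this assay the estimate is 18000 nM, with a range from 9000 nM to 36000 nM.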

Compound 4, half-maximal inhibitory concentration: 8350 nM
Compound 4: the middle estimate sits 2.2-fold (0.33 log units) above what was measured; measured number outside the range, below it.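

In this assay, 4-methylphenyl in place of 3-methylphenyl on the aromatic nitrogen gave a 2.1-fold lower number from compound 3 to compound 4 (0.32 log units; beyond the scatter), a modest step, whereas the same change on the other core gave a 1.0-fold higher number from compound 1 to compound 2 (0.02 log units; within the scatter). Within the data shown here, the two steps cannot be told apart, so the data do not show that the change behaves differently on the two cores: the same change on two cores in this assay, a 1.0-fold higher number (0.02 log units; within the scatter) from compound 1 to compound 2 and a 2.1-fold lower number (0.32 log units; beyond the scatter) from compound 3 to compound 4, 2.2-fold (0.34 log units) apart, within the scatter of two such steps Nor do they show that its effect carries over reliably from one core to the other, since the comparison rests on only two pairs, one with a step within the scatter and one with a modest step beyond it.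

The compounds shown leave open whether a longer chain such as ethyl or propyl in place of the methyl, or a carboxylic acid or an amine on that phenyl, would change the number in this assay. They also leave open whether any such replacement would give similar steps on both cores.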